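Alkoxy in place of alkyl on the amide of compound 1

A few compounds are considered here, and "the series" means these few. Any claim that something is new, unique, unknown or untested is made for them only; others in the source may bear on it.

Measured compounds:
compound 1 `CCCCCCCNC(=O)[C@H]1OC(n2cnc3c(N)ncnc32)[C@H](O)[C@@H]1O` — 20 nM
compound 2 `CC(C)(C)NC(=O)[C@H]1O[C@@H](n2cnc3c(N)ncnc32)[C@H](O)[C@@H]1O` — 6850 nM
compound 3 `Nc1ncnc2c1ncn2[C@@H]1O[C@H](C(=O)NC2CCCCC2)[C@@H](O)[C@H]1O` — 18 nM

In an assay on cell membranes for binding affinity to 2-oxoglutarate receptor 1 (Rattus norvegicus), read by radioligand binding (a lower number here means a stronger inhibitor, a higher number a weaker inhibitor), compound 1 gives 20 nM, the second highest of the three numbers; it lies within the scatter of compound 3, which gives 18 nM, and far from compound 2, which gives 6850 nM. The unmeasured compound 4 `CC(C)CONC(=O)[C@H]1OC(n2cnc3c(N)ncnc32)[C@H](O)[C@@H]1O` arises from compound 1 by the change (isobutoxy in place of heptyl on an amide-type nitrogen). Within the data shown here, the only measured step at the same place is a 380-fold lower number from compound 2 to compound 3 (2.58 log units; beyond the scatter), which shows how strongly the number at this amide-type nitrogen can move with the group attached there. Among the measured compounds shown here, no measured compound carries an alkoxy group on that nitrogen, so the direction of the step to compound 4 cannot be read from a directly matching pair. Given the wide range seen at this position, compound 4 is expected to give a higher number than compound 1 in this assay, a step of a 10-fold higher number from compound 1 to compound 4 (1.00 log units; beyond the scatter), with much uncertainty. Compound 4 is therefore estimated at 200 nM, in the range 30 nM to 2000 nM.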

Compound 4, inhibition constant: 20 nM
Estimate against measurement, compound 4: 10-fold (1.00 log units) above; the measured number lies below the stated range.
By their numbers in this assay, from the lowest: compounds 3, 1 and 4 (each within the scatter of the next); then compound 2.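

Placing isobutoxy instead of heptyl on the amide-type nitrogen gives no change at the digits printed from compound 1 to compound 4 (within the scatter) in this assay. Among these compounds, the earlier 380-fold lower number from compound 2 to compound 3 (2.58 log units; beyond the scatter) showed only that the number can move strongly with the carbon group on this nitrogen, whereas this new step shows that a group attached through oxygen, with fewer heavy atoms than heptyl, can hold the number where compound 1 has it. Nothing available explains why the number holds across this change.

On these data alone, it remains open whether isobutyl without the oxygen, or heptyloxy with the oxygen and the longer chain together, would give a similar number at this nitrogen. Also open, as far as these compounds go, is how the number would respond to an amine or a carboxylic acid at the end of the chain.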